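Amine variation on the shared quinone core: compound 4

This account rests on a few compounds, and the source may have more. Where it says the series, first, only, none or still open, it means among the compounds named here.

Measured so far in a functional assay on ECa-109 cells for inhibition, with ECa-109 cell line (Homo sapiens) as the target, read by sulforhodamine B assay; a higher number here means a weaker inhibitor, a lower number a stronger inhibitor:
compound 1 `O=C1C=C(Nc2ccc(I)cc2)C(=O)c2c1nc1n2[C@H]2OC[C@@H](O)[C@H]2OC1` — 2300 nM
compound 2 `O=C1C=C(NC2CCCCC2)C(=O)c2c1nc1n2[C@H]2OC[C@@H](O)[C@H]2OC1` — > 16000 nM, a limit of the assay
compound 3 `O=C1C=C(N2CCCCC2)C(=O)c2c1nc1n2[C@H]2OC[C@@H](O)[C@H]2OC1` — > 8000 nM, a limit of the assay

Compound 3 stands at the limit of > 8000 nM in this assay, at which 1 of the 3 values shown sits, so no number of its own is known for it; it sits only at that limit. Against compound 1 the step of an at least 3.4-fold higher number from compound 1 to compound 3 (0.54 log units; beyond the scatter) is beyond the scatter, so compound 3 is at least modestly the weaker of the two. The step that the two limits leave unreadable from compound 2 to compound 3 stays unreadable, as both ends are limits.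

Compound 4 `CCCN(CCC)C1=CC(=O)c2nc3n(c2C1=O)[C@H]1OC[C@@H](O)[C@H]1OC3` differs from compound 3 by dipropylamino in place of piperidin-1-yl on a double-bonded ring carbon. Both groups are tertiary amines without a hydrogen-bond donor; the change opens the six-membered ring into two propyl chains. For the measured compounds named here, the steps that bear on it, from compound 1 to compound 3 and from compound 2 to compound 3, both end at a limit, and nothing among the measured compounds separates a ring amine from an open-chain amine at this position. The expectation is therefore that compound 4 remains at or near the limit, with the step that the limit leaves unreadable from compound 3 to compound 4 expected to stay within the scatter. Compound 4 is estimated at 10000 nM, in the range 4000 nM to 40000 nM, most likely reported only as a limit.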

Compound 4, half-maximal inhibitory concentration: > 16000 nM
Compound 4 gave a limit, no number; the forecaster's own chance of this, stated with the estimate: 65%; middle value at least 1.6-fold (0.20 log units) away from the limit.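

In this assay, compound 4 sits at a limit of the assay, not at a number of its own, and it shares that limit with compound 2: the limit of > 16000 nM in this assay, at which 2 of the 4 values shown sit.

With dipropylamino in place of (4-iodophenyl)amino, the result is an at least 6.9-fold higher number from compound 1 to compound 4 (0.84 log units; beyond the scatter), so an open-chain amine now joins the piperidin-1-yl and cyclohexylamino groups as clearly weaker than the one arylamino group shown. The steps to compound 4 from compound 2 and from compound 3 cannot be read, as both ends of each are limits, so the compounds shown give no order among these three amines.

For the compounds shown here, with only one arylamino group, it stays open whether the value of compound 1 depends on the phenyl ring or on the iodine, a question that an unsubstituted phenylamino group or a 4-chlorophenylamino group would help to settle. From the compounds shown here alone, it also stays open whether a benzylamino group, with one carbon between the nitrogen and the phenyl ring, would keep a measurable value or fall to a limit like compound 2, compound 3 and compound 4.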